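Cytotoxicity on rat L6 cells across a small amine series

The compounds below may be only part of what the source reports. "The series", "measured", "known", "first", "only" and "open" are said of these compounds alone.

Measured compounds:
compound 1 `CN(C)C12CCN(CCN3CCCC3)C(C(c3ccccc3)C1)C(c1ccccc1)C2` gives 80400 nM
compound 2 `CN(C)C12CCN(CCCN3CCCCC3)C(C(c3ccccc3)C1)C(c1ccccc1)C2` gives 58400 nM
compound 3 `c1ccc(C2CC3(N4CCCCC4)CCN(CCN4CCCC4)C2C(c2ccccc2)C3)cc1` gives 156000 nM

In an ADME assay on L6 cells (Rattus norvegicus) for cytotoxicity (on this read-out lower numbers stand for stronger inhibition and higher numbers for weaker inhibition), the three measured compounds sit close together. Compound 3 differs from compound 1 by piperidin-1-yl in place of dimethylamino on a saturated ring carbon; that change gives a 1.9-fold higher number from compound 1 to compound 3 (0.29 log units; within the scatter). Compound 2 differs from compound 1 by (piperidin-1-yl)methyl in place of pyrrolidin-1-yl on a saturated chain carbon, two bonds along the chain from an amine nitrogen in a ring; that change gives a 1.4-fold lower number from compound 1 to compound 2 (0.14 log units; within the scatter).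

Compound 4 `c1ccc(C2CC3(N4CCCCC4)CCN(CCCN4CCCCC4)C2C(c2ccccc2)C3)cc1` is not yet measured. It differs from compound 3 by (piperidin-1-yl)methyl in place of pyrrolidin-1-yl on a saturated chain carbon, two bonds along the chain from an amine nitrogen in a ring, the same change as from compound 1 to compound 2, made on the core of compound 3. Since that earlier step stayed within the scatter, the step from compound 3 to compound 4 is expected to be about a 1.4-fold lower number from compound 3 to compound 4 (0.15 log units; within the scatter). Compound 4 is therefore estimated at 110000 nM, with a range from 55000 nM to 220000 nM.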

Compound 4, half-maximal inhibitory concentration: 138000 nM
For compound 4 the middle estimate is 1.3-fold (0.10 log units) below the measured one; measured number inside the range.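

In this assay, (piperidin-1-yl)methyl in place of pyrrolidin-1-yl gives a 1.1-fold lower number from compound 3 to compound 4 (0.05 log units; within the scatter), and this change carries from one core to the other without a measurable difference: the same change on two cores in this assay, a 1.4-fold lower number (0.14 log units; within the scatter) from compound 1 to compound 2 and a 1.1-fold lower number (0.05 log units; within the scatter) from compound 3 to compound 4, 1.2-fold (0.09 log units) apart, within the scatter of two such steps

Piperidin-1-yl in place of dimethylamino gives a 2.4-fold higher number from compound 2 to compound 4 (0.37 log units; beyond the scatter), and it also agrees with its earlier counterpart: the same change on two cores in this assay, a 1.9-fold higher number (0.29 log units; within the scatter) from compound 1 to compound 3 and a 2.4-fold higher number (0.37 log units; beyond the scatter) from compound 2 to compound 4, 1.2-fold (0.09 log units) apart, within the scatter of two such steps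

This agreement rests on two cores and four compounds only, and the chain change stays within the scatter on both cores, so it shows a small step recurring rather than a clear effect being transferred.

Open, from the compounds shown here alone, is how other groups would read on the same saturated ring carbon, such as morpholin-4-yl or diethylamino. Also open, going by these compounds, is whether a longer chain ending in piperidin-1-yl would follow the same small step.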